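Notes on the amide terminus of the shared core

The compounds below may be only part of what the source reports. "The series", "measured", "known", "first", "only" and "open" are said of these compounds alone.

Measured so far:
compound 1 `O=C(CCC(=O)OCCCCCCSc1ccc([N+](=O)[O-])c2nonc12)Nc1cccc(Cl)c1` — compound 1 gives 1920 nM
compound 2 `O=C(CCC(=O)OCCCCCCSc1ccc([N+](=O)[O-])c2nonc12)Nc1ccc(C(F)(F)F)cc1` — compound 2 gives 3200 nM

Both numbers come from a functional assay on HOS cells (Homo sapiens) for inhibition, read by MTT assay, with a stated time of 72 h; a lower number here means a stronger inhibitor, a higher number a weaker inhibitor. Compound 1 stands at the lowest of the two numbers, and the nearest is compound 2: a 1.7-fold higher number from compound 1 to compound 2 (0.22 log units; within the scatter). That single step exchanges the 3-chlorophenyl group for a 4-(trifluoromethyl)phenyl group on the amide-type nitrogen and does not move the number beyond the scatter.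

Compound 3 `O=C(CCC(=O)N1CCCCC1)OCCCCCCSc1ccc([N+](=O)[O-])c2nonc12` is not yet measured in this assay. It differs from compound 1 as follows:
piperidin-1-yl in place of (3-chlorophenyl)amino on a carbonyl carbon

Among the compounds with values here, no measured step bears directly on this change. Within the data shown here, the only step available, a 1.7-fold higher number from compound 1 to compound 2 (0.22 log units; within the scatter), keeps an aromatic ring on the amide-type nitrogen, whereas here a non-aromatic ring replaces the whole (3-chlorophenyl)amino group. With nothing in the series to anchor it, a modest shift toward a higher number is expected, with wide uncertainty.

For compound 3 in this assay the expected value is 3000 nM, within a range from 1200 nM to 8000 nM. As an expected step this reads a 1.6-fold higher number from compound 1 to compound 3 (0.19 log units; within the scatter).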

Compound 3, half-maximal inhibitory concentration: 1790 nM
Estimate against measurement, compound 3: 1.7-fold (0.22 log units) above, within the range that was stated.
By their numbers in this assay, from the lowest: compounds 3, 1 and 2 (each within the scatter of the next).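

In this assay, piperidin-1-yl in place of (3-chlorophenyl)amino on the carbonyl carbon gives a step within the scatter (a 1.1-fold lower number from compound 1 to compound 3 (0.03 log units; within the scatter)), and the same group in place of (4-(trifluoromethyl)phenyl)amino does likewise (a 1.8-fold lower number from compound 2 to compound 3 (0.25 log units; within the scatter)). The earlier pair carried only an aromatic ring on the amide-type nitrogen, so it could speak only to a change of substituent on that ring; compound 3 extends the comparison to a non-aromatic ring and to a terminus that has lost the amide hydrogen. Across compound 1, compound 2 and compound 3, neither the aromatic ring nor the amide hydrogen is needed for a number in this range, and no separate evidence on the reason for this flat result is at hand.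

Still open, from the compounds shown here alone, is whether this insensitivity extends to a morpholin-4-yl group, a free carboxylic acid or a basic amine on the same carbonyl carbon. Equally open, going by these compounds, is whether the terminus matters only once the saturated chain is changed, for example to a longer chain, since all three compounds share the same chain and core.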